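The source may report more compounds than this note shows. Statements on the series, on what has been measured and on what is new or still open speak of the compounds shown alone.

In a functional assay on HCT-8 cells (Homo sapiens) for antiproliferative activity, read by MTT assay, with a stated time of 48 h (a lower number here means a stronger inhibitor, a higher number a weaker inhibitor), compound 1 (`COc1ccc(C(=O)c2ccc(OC)c3c2OC(C)(C)C=C3)c(NC(=O)CN(C)C)c1`) gives 1590 nM. Compound 2 (`C=C(c1cc(OC)c(OC)c(OC)c1)c1ccc(OC)c(O)c1NC(C)=O`) gives 340 nM, and compound 3 (`C=C(c1cc(OC)c(OC)c(OC)c1)c1ccc(OC)c(O)c1NC(=O)COC`) gives 280 nM. The last two values lie within the scatter of each other, so they cannot be ranked. Compound 3 does stand clearly lower than compound 1, which makes it one of the two stronger inhibitors in this small set.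

Compound 4 (`C=C(c1cc(OC)c(OC)c(OC)c1)c1ccc(OC)c(O)c1NC(=O)COCC`) differs from compound 3 by one small change: methyl in place of hydrogen on a saturated chain carbon bound to an oxygen on a saturated carbon, which turns methoxy into ethoxy (methyl in place of hydrogen on a saturated chain carbon bound to an oxygen on a saturated carbon). For the measured compounds named here, only one measured step bears on this change. It placed methoxy in place of hydrogen on a saturated chain carbon bound to a carbonyl carbon, a 1.2-fold lower number from compound 2 to compound 3 (0.08 log units; within the scatter), and it stayed within the scatter. With that single step as the guide, no change beyond the scatter is expected in this assay, and the expected step is a 1.1-fold higher number from compound 3 to compound 4 (0.03 log units; within the scatter). Compound 4 is estimated at 300 nM, with an expected range of 140 nM to 650 nM.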

Compound 4, half-maximal inhibitory concentration: 910 nM
Estimate against measurement, compound 4: 3.0-fold (0.48 log units) below, outside the stated range (above it).
By their numbers in this assay, from the lowest: compounds 3 and 2 (each within the scatter of the next); then compounds 4 and 1 (each within the scatter of the next).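

Adding one methyl to a saturated chain carbon bound to an oxygen on a saturated carbon, which turns methoxy into ethoxy, gives a 3.3-fold higher number from compound 3 to compound 4 (0.51 log units; beyond the scatter) in this assay, so this end of the side chain does respond to a small change. The earlier step from hydrogen to methoxy stayed within the scatter, whereas ethoxy in place of that hydrogen gives a 2.7-fold higher number from compound 2 to compound 4 (0.43 log units; beyond the scatter) and so also marks a weaker inhibitor. Among compounds 2, 3 and 4, methoxy leaves the number within the scatter and ethoxy raises it, but nothing shown here accounts for that difference.

On these data alone, whether a longer chain such as propoxy would raise the number further remains open. So does the effect of a hydroxyl group or an amine at the end of this chain.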